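The compounds below may be only part of what the source reports. "The series", "measured", "known", "first", "only" and "open" are said of these compounds alone.

Measured compounds in a functional assay on CHO cells for agonist activity at Alpha-1D adrenergic receptor (Homo sapiens), read by FLIPR and calcium flux; a lower number here means that less compound is needed, a higher number that more compound is needed for the effect:
compound 1, `CS(=O)(=O)Nc1cccc2c1CCC2c1ncc[nH]1`
compound 2, `Cc1oncc1-c1cccc2c1CCC2c1ncc[nH]1`
compound 3, `Clc1ccc2c(c1-c1cn[nH]c1)CCC2c1ncc[nH]1`
compound 4, `Cn1ccc(-c2cccc3c2CCC3c2ncc[nH]2)n1` — not yet measured

In this assay compound 1 gives > 10000 nM, which is a limit of the assay rather than a number. Compound 2 gives > 10000 nM, again a limit. Compound 3 gives > 10000 nM, also a limit. Compound 2 therefore stands at the same limit as the other two measured compounds; nothing in the numbers sets it apart. Within the data shown here, the only step between compounds that differ in a single place, a step that the two limits leave unreadable from compound 1 to compound 2, cannot be sized, both of its ends being limits. The same picture holds for the whole set, as the limit of > 10000 nM in this assay, at which 3 of the 3 values shown sit, shows.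

Compound 4 differs from compound 2 in one place: 1-methyl-1H-pyrazol-3-yl in place of 5-methyl-1,2-oxazol-4-yl on an aromatic carbon. Both groups are one five-membered aromatic ring with 2 hetero atoms, and the change sits on the same aromatic carbon. Among the measured compounds shown here, no measured step bears directly on this change, and the one step present is unreadable, so no direction can be drawn from the data; what the data do show is that every value so far sits at the limit. Compound 4 is expected to give 15000 nM, with a range of 4000 nM to 60000 nM. The step this estimate implies, a step that the limit leaves unreadable from compound 2 to compound 4, is expected to stay within the scatter.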

Compound 4, half-maximal effective concentration: > 10000 nM
Compound 4 was reported as a limit; the forecaster's own chance of this, stated with the estimate: 75%; the middle value is on the limit's open side.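

No step to compound 4, whether from compound 1 or from compound 2, can be read, because both ends of each step are limits: the limit of > 10000 nM in this assay, at which 4 of the 4 values shown sit.

The compounds shown leave open how much of any of them would be needed for the effect in this assay, and whether exchanging the groups on the shared core changes that amount.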